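A few compounds are considered here, and "the series" means these few. Any claim that something is new, unique, unknown or untested is made for them only; others in the source may bear on it.

In an assay on HEK293 cells for positive allosteric modulation of metabotropic glutamate receptor 3 (Rattus norvegicus), read by thallium flux, with a stated time of 2.5 min (on this read-out higher numbers stand for larger maximal responses and lower numbers for smaller maximal responses), three compounds have been measured. Compound 1 `Cc1c(OCCCCOc2ccccc2C(=O)O)ccc(C(=O)CC2CCCC2)c1C` gives 28%, compound 3 `Cc1c(OCCCCOc2ccc(F)c(C(=O)O)c2)ccc(C(=O)CC(C)C)c1C` gives 13.8%, and compound 2 `CCC(=O)c1ccc(OCCCCOc2cc(C(=O)O)ccc2OC)c(C)c1O` gives 62.5%. Compound 2 thus stands highest of the three: its number lies beyond the scatter above that of compound 1 and further still above that of compound 3. Compound 4 `COc1ccc(C(=O)O)cc1OCCCCOc1ccc(C(=O)CC(C)C)c(O)c1C` has not yet been measured. It differs from compound 2 in one place: isopropyl in place of methyl on a saturated chain carbon bound to a carbonyl carbon. Among the measured compounds shown here, no measured pair in this set differs only in that place, so the step can only be judged from the whole series. Compound 1 and compound 3 both carry larger groups on the chain carbon bound to the carbonyl carbon than compound 2 does, and both give lower numbers, but each also differs from compound 2 elsewhere, so their values show only a loose hint. Compound 4 is therefore expected to fall somewhat below compound 2, with an estimated step of a number 17.5 percentage points lower from compound 2 to compound 4 (beyond the scatter) in this assay. The estimate for compound 4 is 45%, within a range from 25% to 65%.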

Compound 4, largest response reached (reported as percent of maximum), in percent of the reference or control that the assay uses: 100%
Compound 4: middle estimate off by 55 percentage points, on the low side; the whole stated range lies below it.
By their numbers in this assay, from the lowest: compound 3; then compound 1; then compound 2; then compound 4.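

Among the compounds shown here, the pair gives the first direct reading at this place, on a saturated chain carbon bound to a carbonyl carbon, where the earlier compounds differed in more than one place. In this assay, isopropyl in place of methyl, with the rest of the structure unchanged, gives a number 37.5 percentage points higher from compound 2 to compound 4 (beyond the scatter), so this single change is enough to produce a large gain in maximal response. The direction of this step is opposite to the loose hint drawn from compound 1 and compound 3, which cannot be read as a one-place comparison. Nothing available here accounts for the rise.

The compounds shown leave open whether branching or simply the larger group matters, which a straight propyl or a tert-butyl group at this place would help separate. They also leave open whether the same change would raise the response on the cores of compound 1 and compound 3.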